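This account rests on a few compounds, and the source may have more. Where it says the series, first, only, none or still open, it means among the compounds named here.

Measured compounds:
- compound 1 `CCCCOC(=O)NS(=O)(=O)c1sc(CC(C)C)cc1-c1ccc(CN2C(=O)CCC2=O)cc1`: > 10000 nM
- compound 2 `CCCCOC(=O)NS(=O)(=O)c1sc(CC(C)C)cc1-c1ccc(Cc2ncco2)cc1`: 3.9 nM
- compound 3 `CCCCOC(=O)NS(=O)(=O)c1sc(CC(C)C)cc1-c1ccc(Cc2nccs2)cc1`: 3.2 nM

On these data alone, in an assay on membranes from uterus for displacement of a labelled ligand from Angiotensin type II receptor (Sus scrofa), with a stated time of 1.5 h (on this read-out higher numbers stand for weaker inhibition and lower numbers for stronger inhibition), compound 1 gives only a limit, (the limit of > 10000 nM in this assay, at which 1 of the 3 values shown sits), so its true number is unknown; the other two compounds lie far below it. Compound 4 `CCCCOC(=O)NS(=O)(=O)c1sc(CC(C)C)cc1-c1ccc(C(=O)c2ccnn2C)cc1` is not yet measured; its change from compound 1 is (1-methyl-1H-pyrazol-5-yl)carbonyl in place of (2,5-dioxopyrrolidin-1-yl)methyl on an aromatic carbon. Among the compounds with values here, the steps that bear on it are an at least 2500-fold lower number from compound 1 to compound 2 (3.40 log units; beyond the scatter) and an at least 3100-fold lower number from compound 1 to compound 3 (3.49 log units; beyond the scatter), both large, and each exchanges the same leaving group for a five-membered aromatic ring, though linked through a saturated carbon rather than a carbonyl. A large fall in number is therefore expected for compound 4, estimated as an at least 660-fold lower number from compound 1 to compound 4 (2.82 log units; beyond the scatter). Compound 4 is expected to give about 15 nM, within 2 nM to 150 nM.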

Compound 4, inhibition constant: 3.4 nM
For compound 4 the middle estimate is 4.4-fold (0.64 log units) above the measured one; the measured number falls inside the stated range.
By their numbers in this assay, from the lowest: compounds 3, 4 and 2 (each within the scatter of the next). At a limit, above all of these: compound 1.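

With (1-methyl-1H-pyrazol-5-yl)carbonyl on this aromatic carbon, the link to the ring no longer has to be a saturated carbon: the data show a 1.1-fold higher number from compound 3 to compound 4 (0.03 log units; within the scatter) and a 1.1-fold lower number from compound 2 to compound 4 (0.06 log units; within the scatter), both within the scatter. A pyrazole ring linked through a carbonyl also stands far from the (2,5-dioxopyrrolidin-1-yl)methyl compound, with an at least 2900-fold lower number from compound 1 to compound 4 (3.46 log units; beyond the scatter). That step is open-ended, as compound 1 gives only a limit: the limit of > 10000 nM in this assay, at which 1 of the 4 values shown sits.

On these data alone, the separate contributions of carbonyl and ring remain open, and a (1-methyl-1H-pyrazol-5-yl)methyl group would help to separate them. Whether a plain phenyl ring or an open-chain amide would serve at this position is also unknown.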